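Amino Added to the Saturated Ring of Compound 2

The compounds below may be only part of what the source reports. "The series", "measured", "known", "first", "only" and "open" are said of these compounds alone.

compound 1 `Cc1cc(OC2CCCCC2)c(S(C)(=O)=O)cc1C(=O)N=C(N)N`: 37 nM
compound 2 `Cc1cc(N2CCCCC2)c(S(C)(=O)=O)cc1C(=O)N=C(N)N`: 21 nM

Both were tested in a functional assay for inhibition of sodium/hydrogen exchanger (Oryctolagus cuniculus); a higher number here means a weaker inhibitor, a lower number a stronger inhibitor. Compound 2 gives the lower of the two numbers, but the step of a 1.8-fold lower number from compound 1 to compound 2 (0.25 log units; within the scatter) lies within the scatter, so the two cannot be told apart. Compound 3 `Cc1cc(N2CCC(N)CC2)c(S(C)(=O)=O)cc1C(=O)N=C(N)N` differs from compound 2 by amino in place of hydrogen on a saturated ring carbon, that is, piperidin-1-yl to 4-aminopiperidin-1-yl. Going by the values given here, no measured step adds a group to this saturated ring; the only measured step swaps the ring attachment itself and was small. With nothing pointing either way, the step of no change at the digits printed from compound 2 to compound 3 (within the scatter) is expected to stay within the scatter. The estimate for compound 3 is 21 nM, ranging from 8 nM to 60 nM.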

Compound 3, half-maximal inhibitory concentration: 9.8 nM
Compound 3: middle estimate off by 2.1-fold (0.33 log units), on the high side; the measured number falls inside the stated range.
By their numbers in this assay, from the lowest: compound 3; then compounds 2 and 1 (each within the scatter of the next).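

Amino in place of hydrogen on a saturated ring carbon gives a 2.1-fold lower number from compound 2 to compound 3 (0.33 log units; beyond the scatter) in this assay and is the first single change here to go beyond the scatter, so this ring carbon, three ring bonds from the ring nitrogen, is a place where a new group can shift the number. Replacing cyclohexyloxy with 4-aminopiperidin-1-yl gives a 3.8-fold lower number from compound 1 to compound 3 (0.58 log units; beyond the scatter) as the widest gap among these compounds. Nothing measured here explains the shift.

Still open, as far as these compounds go, is whether amino itself matters, or whether a hydroxyl, a methyl or a carboxylic acid on the same ring carbon would do the same.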